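Shortening the ether chain of compound 2

A few compounds are considered here, and "the series" means these few. Any claim that something is new, unique, unknown or untested is made for them only; others in the source may bear on it.

Measured compounds:
compound 1 `CNC(=O)[C@@H]1C[C@H](N2CCc3ccccc3C2)CN1C(=O)c1ccc(CN)c(OC)c1` — 490 nM
compound 2 `CNC(=O)[C@@H]1C[C@H](N2CCc3c(cccc3OCCC3CC3)C2)CN1C(=O)c1ccc(CN)c(OC)c1` — 2 nM
compound 3 `CNC(=O)[C@@H]1C[C@H](n2cc(C3CC3)nn2)CN1C(=O)c1ccc(CN)c(OC)c1` — 2100 nM

In an assay on isolated protein for inhibition of serine protease 1 (Homo sapiens), read by fluorescence (on this read-out lower numbers stand for stronger inhibition and higher numbers for weaker inhibition), compound 2 gives the lowest number of the three. The step of a 250-fold lower number from compound 1 to compound 2 (2.39 log units; beyond the scatter) separates it from compound 1, the nearest neighbour, and compound 3 at 2100 nM lies furthest away, its own step from compound 1 being a 4.3-fold higher number from compound 1 to compound 3 (0.63 log units; beyond the scatter).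

Compound 4 `CNC(=O)[C@@H]1C[C@H](N2CCc3c(cccc3OC)C2)CN1C(=O)c1ccc(CN)c(OC)c1` differs from compound 2 by hydrogen in place of cyclopropylmethyl on a saturated chain carbon bound to an oxygen on an aromatic ring. Among the compounds with values here, only one measured step bears on this change: a 250-fold lower number from compound 1 to compound 2 (2.39 log units; beyond the scatter), in which the full 2-cyclopropylethoxy group entered in place of hydrogen. Compound 4 keeps methoxy, so the change is a partial reversal of that step. The account therefore expects the number for compound 4 to rise, but by less than the whole step, because the step of a 250-fold lower number from compound 1 to compound 2 (2.39 log units; beyond the scatter) covers a larger change than the one made here. The expected step is a 15-fold higher number from compound 2 to compound 4 (1.18 log units; beyond the scatter). For compound 4 the estimate in this assay is 30 nM, within a range from 5 nM to 200 nM.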

Compound 4, half-maximal inhibitory concentration: 100 nM
For compound 4 the middle estimate is 3.3-fold (0.52 log units) below the measured one, and the stated range covers the measured number.
By their numbers in this assay, from the lowest: compound 2; then compound 4; then compound 1; then compound 3.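

In this assay, within the data shown here, the two new steps divide the gain seen in compound 2 for the first time. Methoxy in place of hydrogen on an aromatic carbon already gives a 4.9-fold lower number from compound 1 to compound 4 (0.69 log units; beyond the scatter) and so accounts for a modest part, while cutting 2-cyclopropylethoxy back to methoxy gives a 50-fold higher number from compound 2 to compound 4 (1.70 log units; beyond the scatter), a large step that shows that most of the gain depends on the atoms beyond methoxy. No supporting evidence is available to explain either step.

This change removes the chain extension and the cyclopropyl ring together, so the compounds shown do not tell which of the two matters. Cyclopropylmethoxy, which keeps the ring on a shorter chain, and n-butoxy, which has a chain but no ring, remain open at this place.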